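This account rests on a few compounds, and the source may have more. Where it says the series, first, only, none or still open, it means among the compounds named here.

Measured compounds:
Compound 1 `CC(=O)N1N=C(c2cccc3ccccc23)CC1/C=C/c1ccccc1` in a functional assay on HEp-2 cells (Homo sapiens) for cytotoxicity, read by sulforhodamine B assay, with a stated time of 48 h (on this read-out lower numbers stand for stronger inhibition and higher numbers for weaker inhibition), gives 21100 nM.
Compound 2 `O=CCN1N=C(c2ccc3ccccc3c2)CC1c1ccccc1` in this assay gives 8400 nM.

Among the compounds with values here, compound 2 carries the lower of the two numbers so far; the value of compound 1 stands higher, and the gap between them is beyond the usual scatter. Within the data shown here, no pairwise step between these two is drawn, as they differ in more than one place.

Compound 3 `O=CCN1N=C(c2ccc3ccccc3c2)CC1c1ccco1` is not yet measured in this assay. It differs from compound 2 in one place: furan-2-yl in place of phenyl on a saturated ring carbon. No step of this kind is shown anywhere in the series, so there is no measured precedent to lean on.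

The change is expected to move the number little, either way, and most likely to stay within the scatter, so the step of a 1.1-fold higher number from compound 2 to compound 3 (0.05 log units; within the scatter) is estimated as close to none. On that basis compound 3 is expected to give about 9500 nM in this assay, in the range 3500 nM to 26000 nM.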

Compound 3, half-maximal inhibitory concentration: 19000 nM
Compound 3: the middle estimate sits 2.0-fold (0.30 log units) below what was measured, and the stated range covers the measured number.
By their numbers in this assay, from the lowest: compound 2; then compounds 3 and 1 (each within the scatter of the next).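

In this assay, within the data shown here, this saturated ring carbon, next to the ring nitrogen, responds to a change of its aromatic ring: furan-2-yl in place of phenyl gives a 2.3-fold higher number from compound 2 to compound 3 (0.35 log units; beyond the scatter), the first single-place step. The step is modest, but it shows that this exchange is not neutral here and that, of this pair, phenyl carries the lower number. Nothing available explains the shift, and ring size and the ring oxygen change together in this one step, so their contributions cannot be separated.

Thiophen-2-yl at this carbon would help separate ring oxygen from ring size, while cyclohexyl would test whether an aromatic ring is needed there at all. From the compounds shown here alone, whether the step holds with a group other than formylmethyl on the ring nitrogen also remains open.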